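This account rests on a few compounds, and the source may have more. Where it says the series, first, only, none or still open, it means among the compounds named here.

In an in vitro ADME assay on microsomes from liver (Rattus norvegicus) for metabolic stability (a lower number here means slower removal, a higher number faster removal of the compound), compound 1 (`CNC[C@]1(O)Cc2ccccc2[C@@H]1Oc1ccccc1CO`) has no usable number: its result reads "not determined" (no result reported). Compound 2 (`CNC[C@]1(O)Cc2ccccc2[C@@H]1Oc1ccc(O)cc1C`), which shares its core, gives 10 mL/min/kg, the only measured clearance available. Compound 3 (`CNC[C@]1(O)Cc2ccccc2[C@@H]1Oc1ccccc1Cl`) carries chloro in place of hydroxymethyl on an aromatic carbon. Going by the values given here, no measured step shows what this change does, so the expectation in this assay is only a modest move toward faster removal relative to compound 2 at 10 mL/min/kg, hardly beyond the usual scatter. For compound 3 the estimated clearance is 15 mL/min/kg, with an expected range of 6 mL/min/kg to 38 mL/min/kg.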

Compound 3, clearance: 10 mL/min/kg
For compound 3 the middle estimate is 1.5-fold (0.18 log units) above the measured one, and the stated range covers the measured number.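

No step can be read between compound 1 and compound 3 in this assay. Compound 1 has no number there. On these data alone, what replacing hydroxymethyl with chloro does to clearance stays open. Nothing shown explains the result of compound 3.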